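Indole amide series: moving the carbonyl on the indole

The source may report more compounds than this note shows. Statements on the series, on what has been measured and on what is new or still open speak of the compounds shown alone.

Compound 3 `COc1ccccc1N1CCN(CCCNC(=O)c2cc3ccc(Br)cc3[nH]2)CC1` gives 69.2 nM in an assay on isolated protein (Vas deferens, strain Sprague-Dawley) for antagonist activity at Alpha-1A adrenergic receptor (Rattus norvegicus), with a stated time of 20 min (a lower number here means tighter binding, a higher number weaker binding), the second highest of the three numbers; compound 1 `COc1ccc2[nH]c(C(=O)NCCCN3CCN(c4ccccc4OC)CC3)cc2c1` gives 77.6 nM and compound 2 `COc1ccccc1N1CCN(CCCNC(=O)c2cc3cc(O)ccc3[nH]2)CC1` gives 55 nM, all three within the scatter of one another. Compound 4 `COc1ccccc1N1CCN(CCCNC(=O)c2cn(C)c3ccccc23)CC1` differs from compound 3 by 1-methyl-1H-indol-3-yl in place of 6-bromo-1H-indol-2-yl on a carbonyl carbon. The measured steps change only the substituent on the indole: a 1.4-fold lower number from compound 1 to compound 2 (0.15 log units; within the scatter) and a 1.3-fold higher number from compound 2 to compound 3 (0.10 log units; within the scatter), both within the scatter. Neither step moves the carbonyl attachment on the indole or removes the hydrogen-bond donor, so they bear only loosely on this change. Because the nearest comparison was a 1.3-fold higher number from compound 2 to compound 3 (0.10 log units; within the scatter), no step beyond the scatter is expected, with direction uncertain. Compound 4 is expected at 90 nM (range 35 nM to 250 nM), the expected step being a 1.3-fold higher number from compound 3 to compound 4 (0.11 log units; within the scatter).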

Compound 4, dissociation constant: 52.5 nM
The estimate for compound 4 lay 1.7-fold (0.23 log units) above the measured number; measured number inside the range.
By their numbers in this assay, from the lowest: compounds 4, 2, 3 and 1 (each within the scatter of the next).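

In this assay, putting 1-methyl-1H-indol-3-yl on the carbonyl carbon gives a 1.3-fold lower number from compound 3 to compound 4 (0.12 log units; within the scatter) and a 1.0-fold lower number from compound 2 to compound 4 (0.02 log units; within the scatter). Unlike the earlier steps, these change the attachment on the indole, and the first also loses the hydrogen-bond donor counted on 6-bromo-1H-indol-2-yl, yet both stay within the scatter. No evidence bears on this result. Still open, from the compounds shown here alone, is whether the methyl or the altered attachment alone would stay within the scatter. An amine or a carboxylic acid on the indole also remains to be read in this assay.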